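Swapping methoxy for methyl on a nitro-bearing stilbene

The source may hold more compounds than are shown below. What is called first, only, known or untested is meant among the compounds shown, and "the series" means these compounds.

Compound 3 `COc1ccc(/C=C/c2cccc([N+](=O)[O-])c2)cc1` is assessed in an assay on HepG2 cells for activation of nuclear factor erythroid 2-related factor 2 (Homo sapiens), read by a luciferase reporter, with a stated time of 5 h (a higher number here means that more compound is needed for the effect, a lower number that less compound is needed), where compound 3 gives 3300 nM. This is the highest of the two numbers shown. The nearest compound is compound 1 `Cc1ccc(/C=C/c2cccc(F)c2)cc1`, which in this assay gives 800 nM; compound 1 differs from compound 3 in two places, so the two values are simply recorded side by side. Compound 2 `COc1ccc(/C=C/c2cccc(O)c2)cc1` reaches only a limit of this assay, with > 15000 nM for compound 2, and a limit is not a number. Going by the values given here, the one measured step, nitro in place of hydroxy on an aromatic carbon, gives an at least 4.5-fold lower number from compound 2 to compound 3 (0.65 log units; beyond the scatter).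

Compound 4 `Cc1ccc(/C=C/c2cccc([N+](=O)[O-])c2)cc1` differs from compound 3 by methyl in place of methoxy on an aromatic carbon. Among the compounds with values here, no measured step changes this position on its own, so nothing recorded bears directly on the size of this step, and it is expected to stay within the scatter or to be at most modest in either direction. The step from compound 3 to compound 4 is therefore estimated at a 1.3-fold lower number from compound 3 to compound 4 (0.12 log units; within the scatter). For compound 4 in this assay the value is estimated at 2500 nM, expected to lie between 1000 nM and 6500 nM.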

Compound 4, half-maximal effective concentration: 3700 nM
For compound 4 the middle estimate is 1.5-fold (0.17 log units) below the measured one; the measured number falls inside the stated range.
By their numbers in this assay, from the lowest: compound 1; then compounds 3 and 4 (each within the scatter of the next). At a limit, above all of these: compound 2.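

In this assay, the position on an aromatic carbon para to a large group now has its first direct reading: methyl in place of methoxy gives a 1.1-fold higher number from compound 3 to compound 4 (0.05 log units; within the scatter), so with nitro held constant, this exchange leaves the number within the scatter. The same compound also opens a second comparison, at the place that carries nitro, where nitro in place of fluoro with methyl held constant gives a 4.6-fold higher number from compound 1 to compound 4 (0.67 log units; beyond the scatter), a step beyond the scatter and the larger of the two new steps. Nothing recorded here explains either step.

On these data alone, the methoxy-to-methyl step has been read only with nitro on the shared core, so it remains open whether the two groups would also match with fluoro or hydroxy at that other place. Going by these compounds alone, it is equally open how far this position accepts groups of another kind, such as an amine, a carboxylic acid or a longer chain, as methyl and methoxy are the only two groups compared there on their own.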